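A few compounds are considered here, and "the series" means these few. Any claim that something is new, unique, unknown or untested is made for them only; others in the source may bear on it.

Of the compounds shown here, three have been tested so far, all in a functional assay on Hep 3B2 cells (Homo sapiens) for inhibition, read by sulforhodamine B assay, with a stated time of 72 h; a lower number here means a stronger inhibitor, a higher number a weaker inhibitor. Compound 1 `Cc1ccc2c(c1)c([C@H](C)Nc1ncnc3[nH]cnc13)nn2-c1cccnc1` gives > 40000 nM as a limit of the assay and not a number. Compound 2 `C[C@H](Nc1ncnc2[nH]cnc12)c1nn(-c2cccc(F)c2)c2cc(F)ccc12` gives > 40000 nM, which is also a limit. Compound 3 `C[C@H](Nc1nc(N)nc2[nH]cnc12)c1nn(-c2cccnc2)c2cc(F)ccc12` gives > 40000 nM, again a limit. Compound 2 therefore has no exact value, and it stands level with the other two. Compound 4 `C[C@H](Nc1ncnc2[nH]cnc12)c1nn(-c2ccc(C#N)cc2)c2cc(F)ccc12` carries 4-cyanophenyl in place of 3-fluorophenyl on an aromatic nitrogen of the shared core. Going by the values given here, the expected step of a number no higher from compound 2 to compound 4 (the limit leaves the size open) stays within the scatter, in no clear direction, because the limit of > 40000 nM in this assay, at which 3 of the 3 values shown sit, and no tested compound gives an exact number. For compound 4 the estimate is 40000 nM with an expected range from 15000 nM to 60000 nM and a limit is the likeliest report.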

Compound 4, half-maximal inhibitory concentration: 13500 nM
Compound 4: middle estimate off by 3.0-fold (0.47 log units), on the high side; measured number outside the range, below it.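

In this assay, 4-cyanophenyl in place of 3-fluorophenyl on an aromatic nitrogen gives an at least 2.9-fold lower number from compound 2 to compound 4 (0.47 log units; beyond the scatter). This shows that a change at this one place can bring a compound off the limit of the assay and give an exact number. The full size of the step cannot be read, because compound 2 has only a limit: the limit of > 40000 nM in this assay, at which 3 of the 4 values shown sit.

The compounds shown do not separate the effect of adding the nitrile from that of removing the fluorine. Going by these compounds, whether a phenyl ring carrying an amine or a carboxylic acid at this place would lower the number further stays open.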